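This account rests on a few compounds, and the source may have more. Where it says the series, first, only, none or still open, it means among the compounds named here.

Going by the values given here, the three compounds measured so far share one core and differ only in the aromatic group on the ring nitrogen. In an assay on HEK293 cells for inhibition of Voltage-dependent T-type calcium channel subunit alpha-1G (Homo sapiens), read by fluorescence, tested at 10 uM (a lower number here means less inhibition, a higher number more inhibition at the concentration tested (going by the name of the read-out)), compound 1 `CCCc1nc(-c2ccccc2)c(CNCCCN2CCN(c3cccc(OC)c3)CC2)o1` gives 36.4%, compound 2 `CCCc1nc(-c2ccccc2)c(CNCCCN2CCN(c3ccc(C(F)(F)F)cc3)CC2)o1` gives 51.6%, and compound 3 `CCCc1nc(-c2ccccc2)c(CNCCN2CCN(c3ccccn3)CC2)o1` gives 48.1%. Compound 3 thus stands second highest of the three numbers: its value and that of compound 2 lie within the usual scatter of each other, while its value is beyond the scatter above that of compound 1.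

Compound 4 `CCCc1nc(-c2ccccc2)c(CNCCN2CCN(c3ccccc3)CC2)o1` differs from compound 3 in one place: phenyl in place of pyridin-2-yl on an amine nitrogen in a ring. Among the compounds with values here, the one measured step at the same place, a number 15.2 percentage points higher from compound 1 to compound 2 (beyond the scatter), shows that swapping the aromatic group on the ring nitrogen can move the read-out by a modest amount, but that step concerns two other groups and gives no direct guide for phenyl against pyridin-2-yl. Because the step of a number 15.2 percentage points higher from compound 1 to compound 2 (beyond the scatter) was modest and the groups exchanged here are both single six-membered aromatic rings, the step of a number 0.1 percentage points lower from compound 3 to compound 4 (within the scatter) is expected to stay small, with no confident direction. On that basis compound 4 is estimated to give 48% in this assay, within a range from 33% to 63%.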

Compound 4, a percentage reported as inhibition, at one concentration (the size of the read-out at that concentration, not a potency): 54.3%
Estimate against measurement, compound 4: 6.3 percentage points below, and the stated range covers the measured number.
By their numbers in this assay, from the lowest: compound 1; then compounds 3, 2 and 4 (each within the scatter of the next).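

At the amine nitrogen in the ring, the step of a number 6.2 percentage points higher from compound 3 to compound 4 (within the scatter) in this assay shows that a pyridin-2-yl group, with one ring nitrogen and one hydrogen-bond acceptor, can give way to a phenyl group, with neither, without a change beyond the usual scatter. Going by these compounds alone, the only earlier step at this place, a number 15.2 percentage points higher from compound 1 to compound 2 (beyond the scatter), lay beyond the scatter, but it exchanged two substituted phenyl groups, so this new step is the first to test the ring nitrogen of the aromatic group on its own, and that atom shows no measurable role in this pair. No measurement is available that would explain this result.

The compounds shown leave open whether a non-aromatic ring such as cyclohexyl, or a phenyl ring carrying a carboxylic acid, would keep the read-out within the scatter of compound 4. As far as these compounds go, the read-out is also taken at a single concentration, so it remains open whether compound 3 and compound 4 would match in potency across a range of concentrations.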